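Two fluorines swap places; weak cytotoxicity expected to persist

The compounds below may be only part of what the source reports. "The series", "measured", "known", "first", "only" and "open" are said of these compounds alone.

Compound 1 `Fc1ccc(/C=N/NC(=S)Nc2cccc3ccccc23)cc1Cl`: in an ADME assay on NIH3T3 cells (Mus musculus) for cytotoxicity, read by XTT assay, with a stated time of 24 h (a higher number here means a weaker inhibitor, a lower number a stronger inhibitor), compound 1 gives 500 ug/mL.
Compound 2 `Fc1cc(F)cc(/C=N/NC(=S)Nc2cccc3ccccc23)c1`: in this assay compound 2 gives > 500 ug/mL, which is a limit of the assay rather than a number.
Compound 3 `Fc1ccc(Oc2ccc(/C=N/NC(=S)Nc3cccc4ccccc34)cc2)cc1`: in this assay compound 3 gives > 500 ug/mL, again a limit.

Compound 2 thus sits at the limit of > 500 ug/mL in this assay, at which 2 of the 3 values shown sit, meaning only weak cytotoxicity is seen. Among the measured compounds shown here, the single measured step, a number no lower from compound 1 to compound 2 (the limit leaves the size open), ends at that limit, so its size cannot be read. Compound 4 `Fc1ccc(/C=N/NC(=S)Nc2cccc3ccccc23)c(F)c1` differs from compound 2 in one place: 2,4-difluorophenyl in place of 3,5-difluorophenyl on a carbon with a double bond to nitrogen. For the measured compounds named here, the only step that bears on this change is the one from compound 1 to compound 2, which stayed at or beyond the limit. For compound 4 I therefore expect a number no higher from compound 2 to compound 4 (the limit leaves the size open), no step beyond the scatter. Compound 4 is estimated at 500 ug/mL, within 250 ug/mL to 1000 ug/mL.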

Compound 4, half-maximal inhibitory concentration: > 500 ug/mL
Compound 4 gave a limit, no number; the forecaster's own chance of this, stated with the estimate: 60%; the middle value sits exactly at the limit.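

In this assay compound 4 gives > 500 ug/mL, which is a limit of the assay. This position has now carried two difluorophenyl groups with the same atoms joined differently, and neither gives a number, so the step between compound 2 and compound 4 cannot be read. The remaining step shows a number no lower from compound 1 to compound 4 (the limit leaves the size open) and gives a direction only. The values shown gather at one edge of the scale: the limit of > 500 ug/mL in this assay, at which 3 of the 4 values shown sit.

Going by these compounds, how far past the limit compound 2 and compound 4 lie stays open, so the two groups cannot be ranked. Also open, on these data alone, is whether a phenyl group bearing an amine or a carboxylic acid at this position would give a readable number.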